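The source may hold more compounds than are shown below. What is called first, only, known or untested is meant among the compounds shown, and "the series" means these compounds.

Compound 1 `CCc1ccc(-c2nc3ccccc3[nH]2)nc1` and compound 2 `CCc1cccc(-c2nc3ccccc3[nH]2)n1` are built from the same atoms joined differently; the difference between the two cores is not broken down here. In a functional assay on the whole organism with Rattus norvegicus as the target, read by paw edema, with a stated time of 3 h, at a dose of 100 mg/kg by the oral route (a lower number here means less inhibition, a higher number more inhibition at the dose given (going by the name of the read-out)), compound 1 gives 44%, and in this assay compound 2 gives 41%, a pair of numbers that sit within the usual scatter of each other. Compound 3 `OCc1ccc(-c2nc3ccccc3[nH]2)nc1` carries hydroxy in place of methyl on a saturated chain carbon bound to an aromatic carbon relative to compound 1, and in this assay compound 3 gives -10%. That single change produced a number 54 percentage points lower from compound 1 to compound 3 (beyond the scatter).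

Compound 4 `OCc1cccc(-c2nc3ccccc3[nH]2)n1` has not been measured. It stands to compound 2 exactly as compound 3 stands to compound 1: the change is hydroxy in place of methyl on a saturated chain carbon bound to an aromatic carbon, and the two place descriptions are the same word for word. Within the data shown here, with only one measured instance of this change, the expectation rests on it alone. In this assay, among the measured compounds shown here, the step is expected to be a number 49 percentage points lower from compound 2 to compound 4 (beyond the scatter), a large drop of about the same size as the one seen from compound 1 to compound 3, because compound 3 gave -10%. Compound 4 is therefore estimated at -8%, expected to fall between -30% and 15%.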

Compound 4, a percentage reported as inhibition, in the whole organism at one dose (the size of the read-out at that dose, not a potency): -13%
The estimate for compound 4 lay 5 percentage points above the measured number; low and high end bracket the measured number.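

In this assay, hydroxy in place of methyl on a saturated chain carbon bound to an aromatic carbon gives a number 54 percentage points lower from compound 2 to compound 4 (beyond the scatter), so the large loss seen on the core of compound 1 recurs on the core of compound 2. Set beside the earlier step, the change carries over between these two cores with no difference beyond the scatter: the same change on two cores in this assay, a number 54 percentage points lower (beyond the scatter) from compound 1 to compound 3 and a number 54 percentage points lower (beyond the scatter) from compound 2 to compound 4, 0 percentage points apart, within the scatter of two such steps

This rests on just two instances, on two cores built from the same atoms and read at a single dose and time, so it shows that the step carries over between these two cores only; it does not show that the step would hold on any other core, nor does it explain why the number falls.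

The compounds shown carry only ethyl or hydroxymethyl at this place, so it stays open how an amine, a carboxylic acid or a longer chain such as propyl would read in this assay. Also open, going by these compounds, is how ethyl and hydroxymethyl would compare on a core other than those of compound 1 and compound 2.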